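Nitro for methoxy at a solubility limit

A few compounds are considered here, and "the series" means these few. Any claim that something is new, unique, unknown or untested is made for them only; others in the source may bear on it.

Measured in a physicochemical assay for solubility, in phosphate buffer; on this read-out higher numbers stand for higher solubility and lower numbers for lower solubility:
- compound 1 `Cc1cc(N[C@H](CCCCNCc2cccc(F)c2)C(=O)NO)cc(C)c1F`: > 5 ug/mL
- compound 2 `Cc1ccc(CNCCCC[C@@H](Nc2cc(C)c(F)c(C)c2)C(=O)NO)cc1`: > 5 ug/mL
- compound 3 `COc1ccc(CNCCCC[C@@H](Nc2cc(C)c(F)c(C)c2)C(=O)NO)cc1`: > 5 ug/mL

Compound 3 stands at > 5 ug/mL, which is a limit and not a number. The series offers nothing firmer: the limit of > 5 ug/mL in this assay, at which 3 of the 3 values shown sit. Compound 4 `Cc1cc(N[C@H](CCCCNCc2ccc([N+](=O)[O-])cc2)C(=O)NO)cc(C)c1F` carries nitro in place of methoxy on an aromatic carbon. The closest measured change is a step that the two limits leave unreadable from compound 2 to compound 3, which alters the group at this same place. The other two are a step that the two limits leave unreadable from compound 1 to compound 2 and a step that the two limits leave unreadable from compound 1 to compound 3. None of the three has a readable size, so they support no direction and no step beyond the scatter in this assay. The expected change is a step that the limit leaves unreadable from compound 3 to compound 4. For compound 4 the estimated value is 10 ug/mL, with an expected range from 4 ug/mL to 30 ug/mL.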

Compound 4, solubility: > 5 ug/mL
Compound 4: a limit, no number (the forecaster's own chance of this, stated with the estimate: 70%); the middle value lies beyond the limit too.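

In this assay, for the compounds shown here, compound 4 gives > 5 ug/mL as a limit and not a number, so no step from compound 1, compound 2 or compound 3 to compound 4 can be read. The compounds shown leave open how far their solubilities actually differ, since all of the values share one limit: the limit of > 5 ug/mL in this assay, at which 4 of the 4 values shown sit.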